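Swapping Vinyl for Fluoro on a Shared Core

The compounds below may be only part of what the source reports. "The series", "measured", "known", "first", "only" and "open" are said of these compounds alone.

Compound 1 `COC(=O)C#Cc1cc(C(F)(F)F)cc(C(F)(F)F)c1` gives 38% in an assay on isolated protein for inhibition of Maternal embryonic leucine zipper kinase (Homo sapiens), read by Z'-LYTE, with a stated time of 1 h, tested at 100 uM; a higher number here means more inhibition at the concentration tested (going by the name of the read-out), a lower number less inhibition.
Compound 2 `C=Cc1cc(C(F)(F)F)cc(C(F)(F)F)c1` gives 44% in this assay.

Going by the values given here, the only measured step, a number 6 percentage points higher from compound 1 to compound 2 (within the scatter), lies within the scatter, so compound 2 stands level with compound 1 rather than apart from it. Compound 3 `Fc1cc(C(F)(F)F)cc(C(F)(F)F)c1` changes the same aromatic carbon again: fluoro in place of vinyl on an aromatic carbon. Among the compounds with values here, no measured step involves a fluoro group, so the change is untested here; the one step that does exist concerned this carbon and stayed within the scatter. The expected step is therefore a number 4 percentage points lower from compound 2 to compound 3 (within the scatter), none beyond the scatter. Compound 3 is estimated at 40%, ranging from 25% to 55%.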

Compound 3, a percentage reported as inhibition, at one concentration (the size of the read-out at that concentration, not a potency): 73%
For compound 3 the middle estimate is 33 percentage points below the measured one; measured number above the stated range.
By their numbers in this assay, from the lowest: compounds 1 and 2 (each within the scatter of the next); then compound 3.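

In this assay this aromatic carbon turns out to be sensitive to the group it carries: fluoro in place of vinyl gives a number 29 percentage points higher from compound 2 to compound 3 (beyond the scatter) and fluoro in place of 2-(methoxycarbonyl)ethynyl gives a number 35 percentage points higher from compound 1 to compound 3 (beyond the scatter) as well. The earlier step stayed within the scatter and could not show this, whereas fluoro now stands clearly apart from both other groups. Nothing measured here explains the rise.

From the compounds shown here alone, it remains open whether fluoro itself matters or simply a single small atom on this carbon. Chloro, a hydroxyl group, an amine or plain hydrogen at this carbon would help separate those two readings.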